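The source may report more compounds than this note shows. Statements on the series, on what has been measured and on what is new or still open speak of the compounds shown alone.

Measured in a functional assay on CCRF-CEM cells (Homo sapiens) for inhibition; a lower number here means a stronger inhibitor, a higher number a weaker inhibitor:
Compound 1 `O=C1/C(=C/c2ccc(Cl)cc2)Cc2ccccc21`: 284000 nM
Compound 2 `O=C1/C(=C/c2ccc(Br)cc2)Cc2ccccc21`: 284000 nM

Level with compound 1 in this assay, compound 2 stands at 284000 nM. Among the measured compounds shown here, these two values are the only measurements available so far. Compound 3 `Cc1ccc(/C=C2\Cc3ccccc3C2=O)cc1` has not yet been measured. It differs from compound 2 by a single change: methyl in place of bromo on an aromatic carbon.

For the measured compounds named here, one measured step bears on this change: no change at the digits printed from compound 1 to compound 2 (within the scatter), with bromo in place of chloro on an aromatic carbon. Going by the values given here, that step lies within the scatter, but it is only one step and no measured compound carries the methyl group, so the evidence is thin. No shift beyond the scatter is expected in this assay, and no direction can be favoured. The expected step is no change at the digits printed from compound 2 to compound 3 (within the scatter). For compound 3 the estimated value is 284000 nM, with an expected range of 120000 nM to 650000 nM.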

Compound 3, half-maximal inhibitory concentration: 67100 nM
Compound 3: middle estimate off by 4.2-fold (0.63 log units), on the high side, and the stated range ends above it.
By their numbers in this assay, from the lowest: compound 3; then compounds 1 and 2 (each within the scatter of the next).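

In this assay the group on this aromatic carbon, para to a large group, proves able to shift the number: methyl in place of bromo gives a 4.2-fold lower number from compound 2 to compound 3 (0.63 log units; beyond the scatter) and methyl in place of chloro gives a 4.2-fold lower number from compound 1 to compound 3 (0.63 log units; beyond the scatter) as well. The earlier pair had shown only no change at the digits printed from compound 1 to compound 2 (within the scatter) when one halogen replaced the other, so the position had looked indifferent, and compound 3 now shows that it is not. Nothing measured here accounts for the step.

On these data alone, whether the lower number is particular to methyl or extends to a longer chain such as ethyl, to a methoxy group or to an amine at this place remains open. As far as these compounds go, only compound 3 carries methyl, so whether the step would hold on a different core also remains open.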